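A New Aryl Group on the Ring Carbon of Compound 1

A few compounds are considered here, and "the series" means these few. Any claim that something is new, unique, unknown or untested is made for them only; others in the source may bear on it.

a functional assay on PC-3 cells (Homo sapiens) for antiproliferative activity, read by MTT assay, tested at 1 uM (a lower number here means a weaker effect, a higher number a stronger effect of the compound at the concentration tested), measures how strongly a compound slows the growth of prostate cancer cells in a dish. Among the measured compounds shown here, compound 1 `COc1cc(C2=NN(C(C)=O)C(c3cccc(F)c3)O2)cc(OC)c1OC` gives 16.5% in this assay, the lowest of the three values measured so far. Compound 2 `COc1cc(C(=O)N/N=C/c2cccc(F)c2)cc(OC)c1OC`, built on a different core, gives 53.5%, and compound 3 `COc1cc(C(=O)N/N=C/c2c(Cl)cccc2Cl)cc(OC)c1OC` gives 43%. For the measured compounds named here, the one step among the measured compounds, a number 10.5 percentage points lower from compound 2 to compound 3 (beyond the scatter), swaps the aromatic group on that other core.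

Compound 4 `COc1cc(C2=NN(C(C)=O)C(c3ccc(Cl)c([N+](=O)[O-])c3)O2)cc(OC)c1OC` has not been measured. It differs from compound 1 in one place: 4-chloro-3-nitrophenyl in place of 3-fluorophenyl on a saturated ring carbon.

Going by the values given here, the step of a number 10.5 percentage points lower from compound 2 to compound 3 (beyond the scatter) is the only measured change of the aromatic group, but it sits on another core and introduces a different group, so it bears on compound 4 only loosely; it suggests that such a swap moves this assay modestly. I therefore expect a step of a number 1.5 percentage points higher from compound 1 to compound 4 (within the scatter), close to the scatter. For compound 4 the estimate is 18%, with a range from 5% to 35%.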

Compound 4, a percentage reported as inhibition, at one concentration (the size of the read-out at that concentration, not a potency): 43.3%
For compound 4 the middle estimate is 25.3 percentage points below the measured one; measured number above the stated range.
By their numbers in this assay, from the lowest: compound 1; then compounds 3 and 4 (each within the scatter of the next); then compound 2.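

On the core of compound 1, the aryl group on the saturated ring carbon matters: in this assay, 4-chloro-3-nitrophenyl in place of 3-fluorophenyl gives a number 26.8 percentage points higher from compound 1 to compound 4 (beyond the scatter). Among the compounds shown here, the only earlier aryl swap sat on a different core, so this is the first direct sign that a change at this position can move the read-out on this core, and a single replacement is enough to do so. Nothing at hand accounts for this rise.

From the compounds shown here alone, because the entering group differs from the leaving one in several ways at once, it remains open whether the chlorine, the nitro group or the two together matter, and whether the fluorine's removal plays any part. Also open, going by these compounds, is how a ring carrying an amine or a carboxylic acid would behave at this position.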